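This account rests on a few compounds, and the source may have more. Where it says the series, first, only, none or still open, it means among the compounds named here.

Compound 1 `O=C(O)c1ccc(C(=O)/C(=C\c2ccc(Cl)c([N+](=O)[O-])c2)SCc2ccc(Cl)cc2)cc1`: 1000 nM
Compound 2 `COc1ccccc1/C=C(/SCc1ccc(Cl)cc1)C(=O)c1ccc(Cl)cc1`: 1000 nM
Compound 3 `O=C(O)c1ccc(C(=O)/C(=C\c2ccc(Cl)c([N+](=O)[O-])c2)SCc2ccc(F)cc2)cc1`: 1000 nM

All three measured compounds were tested in a functional assay on DU-145 cells (Homo sapiens) for inhibition, read by trypan blue exclusion, with a stated time of 96 h; a lower number here means a stronger inhibitor of growth, a higher number a weaker inhibitor of growth. In this assay compound 1 gives 1000 nM, compound 3 gives 1000 nM, and compound 2 gives 1000 nM. Compounds 1 and 3 share one core and differ in a single place: fluoro in place of chloro on an aromatic carbon. The step this makes is no change at the digits printed from compound 1 to compound 3 (within the scatter), so swapping one halogen for the other at that position left the growth-inhibiting power unchanged within the usual scatter of such measurements.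

Compound 2 is built on a different core, and how the core of compound 1 and the core of compound 2 differ is not broken down here. What can be said is that compound 2 stands level with both compound 1 and compound 3 at the digits reported.

Compound 4 `COc1ccccc1/C=C(/SCc1ccc(F)cc1)C(=O)c1ccc(Cl)cc1` has not yet been measured. It differs from compound 2 by fluoro in place of chloro on an aromatic carbon. The place of this change is described in exactly the same words as for the pair of compound 1 and compound 3, so it is the same change, made this time on the core of compound 2.

The step from compound 2 to compound 4 in this assay is expected to be no change at the digits printed from compound 2 to compound 4 (within the scatter), because the step of no change at the digits printed from compound 1 to compound 3 (within the scatter) on the related core lies within the scatter. Compound 4 is therefore expected to give 1000 nM in this assay, with a likely range from 500 nM to 2000 nM.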

Compound 4, concentration for 50% growth inhibition: 10000 nM
Compound 4: middle estimate off by 10-fold (1.00 log units), on the low side; the whole stated range lies below it.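

In this assay, the swap of 4-chlorobenzyl for 4-fluorobenzyl gives a 10-fold higher number from compound 2 to compound 4 (1.00 log units; beyond the scatter), so on the core of compound 2 this small change of one halogen for another makes compound 4 a weaker inhibitor of growth than compound 2. The same change therefore did not carry over from one core to the other, and its outcome here depends on the core that bears it: the same change on two cores in this assay, no change at the digits printed (within the scatter) from compound 1 to compound 3 and a 10-fold higher number (1.00 log units; beyond the scatter) from compound 2 to compound 4, 10-fold (1.00 log units) apart, beyond the scatter of two such steps

Going by these compounds alone, this does not show which part of the core sets the outcome, since the two cores differ in more than one place and each offers only a single pair, so no general rule for the series follows from these compounds, and no reason for the gap can be read from them.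

Going by these compounds, what stays open is which feature of the cores matters, for instance whether a compound combining the carboxylic acid of compound 1 with the rest of the core of compound 2 would respond to this swap like compound 1 or like compound 4. Also open, on these data alone, is how the core of compound 2 would respond to other groups in the same place, such as bromo, methyl or an amine, and so whether fluoro alone stands apart from chloro there.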